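Prenylated flavanones and cytotoxicity toward THP-1 cells

This account rests on a few compounds, and the source may have more. Where it says the series, first, only, none or still open, it means among the compounds named here.

Compound 1 `CC(C)=CCC/C(C)=C/Cc1c(O)cc2c(c1O)C(=O)C[C@@H](c1cc(O)cc(O)c1)O2` is one of three prenylated flavanones examined in a functional assay on THP-1 cells (Homo sapiens) for cytotoxicity, with a stated time of 72 h; on this read-out higher numbers stand for an effect only at larger amounts of compound and lower numbers for an effect already at smaller amounts. In this assay, within the data shown here, compound 1 gives 8500 nM, the only number among the three results. For compound 2 `COc1cc(O)c([C@@H]2CC(=O)c3c(O)cc(O)cc3O2)cc1C/C=C(\C)CCC=C(C)C` the reading in this assay is a limit of the assay, > 10000 nM. For compound 3 `C=C(C)C(O)CC/C(C)=C/Cc1c(O)cc2c(c1O)C(=O)C[C@@H](c1ccc(O)c(OC)c1)O2` the reading in this assay is likewise a limit, > 10000 nM. Among the measured compounds shown here, compound 1 therefore stands as the sole measured value, and it sits close to the limit of > 10000 nM in this assay, at which 2 of the 3 values shown sit.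

Compound 4 `COc1cc([C@@H]2CC(=O)c3c(cc(O)c(C/C=C(\C)CCC=C(C)C)c3O)O2)cc(O)c1O` has not yet been measured. It differs from compound 1 in one place: 3,4-dihydroxy-5-methoxyphenyl in place of 3,5-dihydroxyphenyl on a saturated ring carbon. For the measured compounds named here, no step between measured compounds exists to indicate how large an effect such a change has here. The step of a 1.1-fold higher number from compound 1 to compound 4 (0.05 log units; within the scatter) is expected to be small, within the usual scatter. Compound 4 is expected to give 9500 nM in this assay, with a range from 4000 nM to 22000 nM. Compound 4 may well also return only a limit.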

Compound 4, half-maximal effective concentration: < 10000 nM
Compound 4 gave a limit, no number; the forecaster's own chance of this, stated with the estimate: 55%; the middle value is on the limit's open side.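

In this assay compound 4 gave a limit of the assay, < 10000 nM, and no number. Among these compounds, no step from compound 1 to compound 4 can be read from this. The compounds shown leave open whether 3,4-dihydroxy-5-methoxyphenyl in place of 3,5-dihydroxyphenyl changes the cytotoxicity at all.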